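Swapping Ethynyl for Bromo on Two Aromatic Cores

The source may report more compounds than this note shows. Statements on the series, on what has been measured and on what is new or still open speak of the compounds shown alone.

Of the compounds shown here, three have been tested in a functional assay on NCI-H522 cells (Homo sapiens) for cytotoxicity, with a stated time of 3 days; on this read-out higher numbers stand for weaker inhibition and lower numbers for stronger inhibition. Compound 1, `C#Cc1nc2ccccc2n1C`, gives 8140 nM in this assay. Compound 2, `C#CCNC(=O)c1csc(C#C)n1`, gives 2100 nM. Compound 3, `C#CCNC(=O)c1csc(Br)n1`, is reported in this assay only as a limit, > 40000 nM, and not as a number. Of the two numbers measured, compound 1 shows the higher one, with compound 2 nearest to it at a lower number.

Compound 2 and compound 3 differ in one place: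

bromo in place of ethynyl on an aromatic carbon

This change produced an at least 19-fold higher number from compound 2 to compound 3 (1.27 log units; beyond the scatter). The true size of that step is not fully known, since it rests on (the limit of > 40000 nM in this assay, at which 1 of the 3 values shown sits).

The unmeasured compound 4, `Cn1c(Br)nc2ccccc21`, is related to compound 1 by the same kind of change:

bromo in place of ethynyl on an aromatic carbon

The surroundings are not identical. In compound 2 the place is on a five-membered aromatic ring with 1 nitrogen and 1 sulfur, next to the ring nitrogen, next to the ring sulfur, two ring bonds from the ring atom that bears a group of 6 heavy atoms. In compound 1 it is on a five-membered aromatic ring with 2 nitrogen, part of a fused or bridged system of two rings, between two ring nitrogen atoms, next to the ring atom that bears a methyl group. The difference between the two cores is not broken down here.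

Within the data shown here, compound 1 already sits at the higher of the two measured numbers, and the one measured example of this kind of change, compound 2 to compound 3, produced an at least 19-fold higher number from compound 2 to compound 3 (1.27 log units; beyond the scatter). On that basis compound 4 is expected to show a 15-fold higher number from compound 1 to compound 4 (1.17 log units; beyond the scatter). For compound 4 the estimated value is 120000 nM, expected to fall between 30000 nM and 500000 nM, and most likely to be reported only as a limit.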

Compound 4, half-maximal inhibitory concentration: > 40000 nM
Compound 4: only a limit was reported; the forecaster's own chance of this, stated with the estimate: 85%; the middle value lies beyond the limit too.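

Putting bromo in place of ethynyl on the core of compound 1 gave an at least 4.9-fold higher number from compound 1 to compound 4 (0.69 log units; beyond the scatter) in this assay, so the number rose on this core as it did on the other. Two different cores therefore agree on the direction of this change, but they cannot yet be compared for its size: the same change on two cores in this assay, an at least 19-fold higher number (1.27 log units; beyond the scatter) from compound 2 to compound 3 and an at least 4.9-fold higher number (0.69 log units; beyond the scatter) from compound 1 to compound 4; the limit leaves it open whether they differ Neither step has a known full size, and two pairs are too few to call this a rule for the whole series, as both bromo compounds rest on the same limit rather than on a number: the limit of > 40000 nM in this assay, at which 2 of the 4 values shown sit.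

The compounds shown leave open how far the numbers of the bromo compounds really lie from those of their ethynyl partners, and whether the same change would raise the number on a third core. Among these compounds, they also leave open whether ethynyl is the only group on this aromatic carbon that goes with a measurable number, since no amine, nitrile or longer chain ending in a triple bond stands in that place here.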